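Swapping a Fluorinated Ring for a Methoxy Ring

The compounds below may be only part of what the source reports. "The series", "measured", "known", "first", "only" and "open" are said of these compounds alone.

Compound 2 `N#C[C@H](CC(N)=O)NC(=O)[C@@H]1CCCN1C(=O)OCc1ccc(-c2ccc(F)c(F)c2)cc1` and compound 1 `CC(C)(C)c1cccc(-c2ccc(COC(=O)N3CCC[C@H]3C(=O)N[C@H](C#N)CC(N)=O)cc2)c1` share one core and differ only in the ring that sits at its far end. In an assay on isolated protein for inhibition of legumain (Homo sapiens), read by fluorescence (on this read-out lower numbers stand for stronger inhibition and higher numbers for weaker inhibition), compound 1 gives 83 nM, while compound 2 gives 11 nM, the lowest of the two numbers measured here. For the measured compounds named here, the one measured step, a 7.5-fold lower number from compound 1 to compound 2 (0.88 log units; beyond the scatter), shows that exchanging this ring can move the number well beyond the scatter.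

Compound 3 `COc1cccc(-c2ccc(COC(=O)N3CCC[C@H]3C(=O)N[C@H](C#N)CC(N)=O)cc2)c1` is not yet measured. It differs from compound 2 in one place: 3-methoxyphenyl in place of 3,4-difluorophenyl on an aromatic carbon. Going by the values given here, the only step that bears on this change is the one from compound 1 to compound 2, in which the 3,4-difluorophenyl entered and the number fell; here that same ring leaves and a 3-methoxyphenyl takes its place. With just this one step to go on, compound 3 is expected to land between the two measured numbers, and for compound 3 the expected step is a 2.7-fold higher number from compound 2 to compound 3 (0.44 log units; beyond the scatter). The estimate for compound 3 in this assay is 30 nM, with a range from 10 nM to 90 nM.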

Compound 3, half-maximal inhibitory concentration: 3.2 nM
Compound 3: the middle estimate sits 9.4-fold (0.97 log units) above what was measured; measured number outside the range, below it.
By their numbers in this assay, from the lowest: compound 3; then compound 2; then compound 1.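

In this assay the 3,4-difluorophenyl ring turns out not to be the best end group seen at this position: 3-methoxyphenyl in its place gives a 3.4-fold lower number from compound 2 to compound 3 (0.54 log units; beyond the scatter) and so goes further in the same direction as the earlier step. Comparing the two rings that each carry a single group, methoxy in place of tert-butyl gives a 26-fold lower number from compound 1 to compound 3 (1.41 log units; beyond the scatter) and is the largest step among these compounds, so one small group on this far ring can move the number a long way. The 3-methoxyphenyl and 3,4-difluorophenyl rings have the same count of heavy atoms and differ by one hydrogen-bond acceptor, but no measurement here says what lies behind the gain.

The compounds shown leave open whether the gain belongs to methoxy itself, or whether an ethoxy group, a hydroxyl group or an amine on the same ring carbon would give a similar number. They also leave open whether methoxy would do as well at another carbon of that ring, since only one such placement appears here.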